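A few compounds are considered here, and "the series" means these few. Any claim that something is new, unique, unknown or untested is made for them only; others in the source may bear on it.

Measured compounds:
- Compound 1, `Nc1sc(-c2ccc(Cl)cc2)c(-c2ccc(Cl)cc2)c1C(=O)NC1CCCCC1`: 7300 nM
- Compound 2, `Nc1sc(-c2ccc(Br)cc2)c(-c2ccc(Cl)cc2)c1C(=O)NC1CCCCC1`: 28400 nM
- Compound 3, `Nc1sc(-c2ccc([N+](=O)[O-])cc2)c(-c2ccc(Cl)cc2)c1C(=O)NC1CC1`: "not determined" (no result reported)

These three compounds share one core and were tested in a functional assay on PC-3 cells (Homo sapiens) for cytotoxicity, read by sulforhodamine B assay, with a stated time of 72 h; a lower number here means a stronger inhibitor, a higher number a weaker inhibitor. Going by the values given here, compound 1 gives 7300 nM in this assay, and compound 2 gives 28400 nM; the one step between them, a 3.9-fold higher number from compound 1 to compound 2 (0.59 log units; beyond the scatter), shows that a single change on one of the aromatic rings can move the number by a modest amount. From the compounds shown here alone, compound 3 stands apart: no number was reported for it in this assay, so its place among the others is unknown.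

Compound 4, `Nc1sc(-c2ccc([N+](=O)[O-])cc2)c(-c2ccc(Cl)cc2)c1C(=O)NC1CCCCC1`, differs from compound 3 in one place: cyclohexyl in place of cyclopropyl on an amide-type nitrogen. Among the compounds with values here, none of the measured steps touches this part of the molecule, since the only step with numbers, a 3.9-fold higher number from compound 1 to compound 2 (0.59 log units; beyond the scatter), concerns a halogen on an aromatic ring while the amide substituent stays the same. The expectation for compound 4 therefore cannot lean on a measured precedent for its own change, and it rests instead on the general level set by compound 1 and compound 2, which both carry the same cyclohexyl amide as compound 4. On that basis compound 4 is estimated at 12000 nM in this assay, with a range from 2500 nM to 60000 nM.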

Compound 4, half-maximal inhibitory concentration: 25900 nM
The estimate for compound 4 lay 2.2-fold (0.33 log units) below the measured number, and the stated range covers the measured number.
By their numbers in this assay, from the lowest: compound 1; then compounds 4 and 2 (each within the scatter of the next).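

Compound 3 has no reported number in this assay, so the change from cyclopropyl to cyclohexyl on the amide-type nitrogen cannot be read, and what compound 4 adds concerns the group on the aromatic carbon instead. With the cyclohexyl amide held constant, nitro in place of bromo makes no difference beyond the scatter (a 1.1-fold lower number from compound 2 to compound 4 (0.04 log units; within the scatter)), whereas nitro in place of chloro gives a modest loss of activity (a 3.5-fold higher number from compound 1 to compound 4 (0.55 log units; beyond the scatter)), so among these three compounds chloro is the only group that stands apart, and bromo and nitro cannot be separated. Nothing available here gives a measured reason for that difference, so the numbers describe the pattern without explaining it.

From the compounds shown here alone, it remains open whether chloro would keep its lead over bromo and nitro with an amide substituent other than cyclohexyl, such as cyclopropyl or a longer carbon chain. Going by these compounds, it is also open how a fluoro, methoxy or amino group on the same aromatic carbon would compare with these three.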